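The source may report more compounds than this note shows. Statements on the series, on what has been measured and on what is new or still open speak of the compounds shown alone.

Measured compounds:
Compound 1, `COc1cc(-n2cnc3ccc(-c4ccccc4Cl)cc32)cc(OC)c1OC`, gives in a functional assay on A549 cells (Homo sapiens) for antiproliferative activity, read by MTT assay, with a stated time of 72 h (on this read-out higher numbers stand for weaker inhibition and lower numbers for stronger inhibition), a value of > 10000 nM, which is a limit of the assay rather than a number.
Compound 2, `COc1ccc(-c2ccc3ncn(-c4cc(OC)c(OC)c(OC)c4)c3c2)cc1F`, gives in this assay 1430 nM.
Compound 3, `COc1cc(-n2cnc3ccc(-c4cccc(O)c4)cc32)cc(OC)c1OC`, gives in this assay 250 nM.

Compound 3 holds the lowest of the two numbers shown, with compound 2 as its nearest neighbour; the third value is only a limit (the limit of > 10000 nM in this assay, at which 1 of the 3 values shown sits). Compound 4, `COc1cc(-n2cnc3ccc(-c4ccc(C)cc4)cc32)cc(OC)c1OC`, has not yet been tested. It differs from compound 3 in one place: 4-methylphenyl in place of 3-hydroxyphenyl on an aromatic carbon.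

For the measured compounds named here, three measured steps bear on this change, all at the same aromatic carbon. The step of an at least 40-fold lower number from compound 1 to compound 3 (1.60 log units; beyond the scatter) and the step of a 5.7-fold lower number from compound 2 to compound 3 (0.76 log units; beyond the scatter) both end at the 3-hydroxyphenyl of compound 3, and the step of an at least 6.9-fold lower number from compound 1 to compound 2 (0.84 log units; beyond the scatter) shows that even a change between two groups lacking that hydroxyl shifts the number beyond the scatter. Removing the 3-hydroxyphenyl in favour of 4-methylphenyl is therefore expected to raise the number in this assay by a modest amount. Compound 4 is estimated at 2000 nM, with a range of 500 nM to 8000 nM. The implied step, an 8.0-fold higher number from compound 3 to compound 4 (0.90 log units; beyond the scatter), is an expectation only.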

Compound 4, half-maximal inhibitory concentration: 1940 nM
Compound 4: the middle estimate sits 1.0-fold (0.01 log units) above what was measured, within the range that was stated.
By their numbers in this assay, from the lowest: compound 3; then compounds 2 and 4 (each within the scatter of the next). At a limit, above all of these: compound 1.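

In this assay, the 3-hydroxyphenyl of compound 3 now stands apart from two other groups at this aromatic carbon: the change to 4-methylphenyl gives a 7.8-fold higher number from compound 3 to compound 4 (0.89 log units; beyond the scatter), whereas the two groups without the hydroxyl are not separated, with a 1.4-fold higher number from compound 2 to compound 4 (0.13 log units; within the scatter). Lacking the hydroxyl is not enough to place a compound with these two, as the 2-chlorophenyl of compound 1 goes against that pattern, with an at least 5.1-fold lower number from compound 1 to compound 4 (0.71 log units; beyond the scatter). That step rests on a limit of the assay and not on a number: the limit of > 10000 nM in this assay, at which 1 of the 4 values shown sits.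

The change removes the hydroxyl and also alters the substituent's place on the phenyl ring, and a 3-methylphenyl or a 4-hydroxyphenyl group would tell these two apart. Going by these compounds, whether a 3-aminophenyl group at this carbon would match 3-hydroxyphenyl also remains open.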